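The compounds below may be only part of what the source reports. "The series", "measured", "known", "first", "only" and "open" are said of these compounds alone.

Compound 3 `COc1cccc([C@@H]2C[C@@H]3Cc4ccc5ccccc5c4N2O3)c1` stands at the top of the numbers shown: in an ADME assay on Vero cells (Chlorocebus sabaeus) for cytotoxicity, read by MTT assay, with a stated time of 72 h (on this read-out lower numbers stand for higher toxicity in this test and higher numbers for lower toxicity in this test), compound 3 gives > 300000 nM, which is a limit of the test rather than a number. Its parent, compound 1 `c1ccc([C@@H]2C[C@@H]3Cc4ccc5ccccc5c4N2O3)cc1`, gives 72900 nM in this assay, so the methoxy compound is less toxic than the unsubstituted one, as the step of an at least 4.1-fold higher number from compound 1 to compound 3 (0.61 log units; beyond the scatter) shows. Compound 2 `Brc1cccc([C@@H]2C[C@@H]3Cc4ccc5ccccc5c4N2O3)c1` gives > 250000 nM in this assay, again a limit. The step of an at least 3.4-fold higher number from compound 1 to compound 2 (0.53 log units; beyond the scatter) is of much the same kind, while the step that the two limits leave unreadable from compound 2 to compound 3 cannot be read, because both values sit at limits, the limit of > 250000 nM in this assay, at which 1 of the 3 values shown sits, and (the limit of > 300000 nM in this assay, at which 1 of the 3 values shown sits).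

The compound not yet measured, compound 4 `Clc1ccc([C@@H]2C[C@@H]3Cc4ccc5ccccc5c4N2O3)c(Cl)c1`, differs from compound 3 by 2,4-dichlorophenyl in place of 3-methoxyphenyl on a saturated ring carbon. Two halogens on the ring resemble the bromo change from compound 1 to compound 2 more than the methoxy one, and both substitutions lowered toxicity beyond the scatter. Compound 4 is therefore expected to remain of low toxicity, with a step of an at least 1.2-fold lower number from compound 3 to compound 4 (0.07 log units; that floor lies within the scatter) that is not expected to exceed the scatter in either direction. The estimate for compound 4 in this assay is 250000 nM, within 70000 nM to 400000 nM, quite possibly reported only as a limit.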

Compound 4, half-maximal cytotoxic concentration: 55000 nM
Compound 4: middle estimate off by 4.5-fold (0.66 log units), on the high side; the whole stated range lies above it.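

Substitution on the phenyl group at this saturated ring carbon does not by itself raise the number in this assay and compound 4 goes against the rise seen with compound 2 and compound 3. The 2,4-dichlorophenyl group gives an at least 5.4-fold lower number from compound 3 to compound 4 (0.73 log units; beyond the scatter) and an at least 4.5-fold lower number from compound 2 to compound 4 (0.65 log units; beyond the scatter) and both of these steps start from a limit of the test rather than a number. Against the unsubstituted phenyl it gives a 1.3-fold lower number from compound 1 to compound 4 (0.12 log units; within the scatter) so that compound 4 cannot be told apart from compound 1 here.

The compounds shown leave open whether the number of chlorines or their place on the ring decides this, whether an amine or a carboxylic acid on the phenyl ring would follow the methoxy group or the chlorines, and how compound 2 and compound 3 compare, a step that still cannot be read. Nothing measured here gives a cause for these steps.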